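The source may report more compounds than this note shows. Statements on the series, on what has been measured and on what is new or still open speak of the compounds shown alone.

In a functional assay on cells for antagonist activity at Free fatty acid receptor 1 (Homo sapiens), read by TR-FRET and inositol phosphate accumulation, with a stated time of 2 h (on this read-out lower numbers stand for stronger inhibition and higher numbers for weaker inhibition), compound 1 `Cc1cc(COc2c(F)cc(F)cc2F)nc(-c2ccccn2)n1` gives 1260 nM, while compound 2 `CC1(C)CN(c2cc(COc3ccc(F)c(F)c3F)nc(-c3ccccn3)n2)C1` gives 25.1 nM, the lowest of the two numbers and a gap beyond the scatter from compound 1. Compound 3 `CC1(COc2cc(COc3ccc(F)c(F)c3F)nc(-c3ccccn3)n2)COC1` carries (3-methyloxetan-3-yl)methoxy in place of 3,3-dimethylazetidin-1-yl on an aromatic carbon. Going by the values given here, no measured pair shows this change, so its direction rests on expectation alone: the step of a 3.2-fold higher number from compound 2 to compound 3 (0.50 log units; beyond the scatter) is estimated to be a loss of modest size, somewhat beyond the scatter. Compound 3 is accordingly expected to give about 80 nM in this assay, with a range from 20 nM to 400 nM.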

Compound 3, half-maximal inhibitory concentration: 79.4 nM
Compound 3: the middle estimate sits 1.0-fold (0.00 log units) above what was measured; low and high end bracket the measured number.
By their numbers in this assay, from the lowest: compound 2; then compound 3; then compound 1.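

In this assay, putting (3-methyloxetan-3-yl)methoxy in place of 3,3-dimethylazetidin-1-yl on this aromatic carbon gives a 3.2-fold higher number from compound 2 to compound 3 (0.50 log units; beyond the scatter), a modest loss that leaves compound 3 still measurable as an inhibitor. Going by these compounds alone, this is the first reading of a change at this position with the rest of the molecule held the same. No measurement given here accounts for the loss. From the compounds shown here alone, it remains open whether the linking oxygen or the oxetane ring carries the step, and how a morpholine or a plain methoxy would read on this carbon.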